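The source may report more compounds than this note shows. Statements on the series, on what has been measured and on what is new or still open speak of the compounds shown alone.

Working notes on the series in a functional assay on A549 cells (Homo sapiens) for inhibition, read by MTT assay, with a stated time of 48 h; a higher number here means a weaker inhibitor, a lower number a stronger inhibitor. Compound 1 (`COc1ccc(C(c2c[nH]c3ccc(Br)cc23)c2c[nH]c3ccc(Br)cc23)c(OC)c1`) gives 100000 nM, compound 2 (`COc1ccc(OC)c(C(c2c[nH]c3ccc(Br)cc23)c2c[nH]c3ccc(Br)cc23)c1`) gives 10000 nM, and compound 3 (`Brc1ccc(C(c2c[nH]c3ccc(Br)cc23)c2c[nH]c3ccc(Br)cc23)cc1`) gives 5600 nM. Compound 3 cannot be separated from compound 2: a 1.8-fold lower number from compound 2 to compound 3 (0.25 log units; within the scatter) stays within the scatter. Against compound 1 the position of compound 3 is clear, with an 18-fold lower number from compound 1 to compound 3 (1.25 log units; beyond the scatter) lying beyond the scatter.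

The next change leads to compound 4 (`CCCCCCCC(c1c[nH]c2ccc(Br)cc12)c1c[nH]c2ccc(Br)cc12`): heptyl in place of 4-bromophenyl on a saturated chain carbon bound to two aromatic carbons, (heptyl in place of 4-bromophenyl on a saturated chain carbon bound to two aromatic carbons). All three measured steps act at this same place, but each exchanges one substituted phenyl for another, so none tests a group without a ring. They show only that this place can matter in this assay, as a 10-fold lower number from compound 1 to compound 2 (1.00 log units; beyond the scatter) was already beyond the scatter. Their size therefore sets a wide range rather than a direct precedent.

With compound 3 at 5600 nM, the expectation leans slightly towards a higher number, though no step beyond the scatter is expected at the centre. The estimated change is a 1.8-fold higher number from compound 3 to compound 4 (0.25 log units; within the scatter). For compound 4 the estimated value is 10000 nM, with an expected range of 3000 nM to 40000 nM.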

Compound 4, half-maximal inhibitory concentration: 3500 nM
Estimate against measurement, compound 4: 2.9-fold (0.46 log units) above; the measured number falls inside the stated range.
By their numbers in this assay, from the lowest: compounds 4, 3 and 2 (each within the scatter of the next, the first and the last beyond it); then compound 1.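

Within the data shown here, at this position on a saturated chain carbon bound to two aromatic carbons, a group with no ring is now seen for the first time, and in this assay the step of a 1.6-fold lower number from compound 3 to compound 4 (0.20 log units; within the scatter) stays within the scatter, so heptyl and 4-bromophenyl cannot be told apart here. An aromatic ring at this place is therefore not needed to keep the number of the best earlier compounds, a point that the earlier phenyl-for-phenyl exchanges could not address. Heptyl does separate from both dimethoxyphenyl groups, with a 2.9-fold lower number from compound 2 to compound 4 (0.46 log units; beyond the scatter) being a modest step and a 29-fold lower number from compound 1 to compound 4 (1.46 log units; beyond the scatter) a large one, and no measurement of any other property accompanies these compounds to account for those differences.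

The compounds shown leave open whether the length of the chain matters, since neither a pentyl nor a decyl chain appears at this carbon, and a single heptyl cannot define a trend. They also leave open how this position responds to a chain ending in an amine or a carboxylic acid, or to an unsubstituted phenyl.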